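The source may report more compounds than this note shows. Statements on the series, on what has been measured and on what is new or still open speak of the compounds shown alone.

Compound 1 `COc1ccc(S(=O)(=O)NCCCN2CCN(c3ccc(C(F)(F)F)cc3)CC2)cc1` gives 384 nM in an assay on CHO cells for displacement of a labelled ligand from 5-hydroxytryptamine receptor 7 (Homo sapiens) (a higher number here means a weaker inhibitor, a lower number a stronger inhibitor), the lower of the two numbers measured. Compound 2 `COc1ccc(N2CCN(CCCNS(=O)(=O)c3ccc(OC)cc3)CC2)cc1` gives 9310 nM, and the step of a 24-fold higher number from compound 1 to compound 2 (1.38 log units; beyond the scatter) shows how much this one group on the shared core can matter. Compound 3 `COc1ccc(S(=O)(=O)NCCCN2CCN(c3ccc(C(C)=O)cc3)CC2)cc1` is not yet measured; it differs from compound 1 by acetyl in place of trifluoromethyl on an aromatic carbon. Among the measured compounds shown here, only the step from compound 1 to compound 2 bears on this change, and it was large, so some loss is expected. For compound 3 the expected step is a 3.1-fold higher number from compound 1 to compound 3 (0.49 log units; beyond the scatter), giving an estimate of 1200 nM with a range from 300 nM to 5000 nM.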

Compound 3, half-maximal inhibitory concentration: > 10000 nM
Compound 3: only a limit was reported; the forecaster's own chance of this, stated with the estimate: 3%; middle value at least 8.3-fold (0.92 log units) away from the limit.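

Acetyl is a second replacement for trifluoromethyl at this position, and it too gives a large change: the step is an at least 26-fold higher number from compound 1 to compound 3 (1.41 log units; beyond the scatter). Both replacements, methoxy and acetyl, therefore give higher numbers than trifluoromethyl, and compound 1 stays the lowest in this assay. The value of compound 3 is a limit of the assay and not a true number: the limit of > 10000 nM in this assay, at which 1 of the 3 values shown sits.

Methoxy and acetyl cannot be put in order: the step is an at least 1.0-fold higher number from compound 2 to compound 3 (0.03 log units; that floor lies within the scatter). Going by these compounds, whether an amine or a carboxylic acid here would give a lower number than trifluoromethyl stays open.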